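Notes on the aromatic-nitrogen substituent in the series

A few compounds are considered here, and "the series" means these few. Any claim that something is new, unique, unknown or untested is made for them only; others in the source may bear on it.

Measured so far:
compound 1 `CC(C)c1onc(-c2c(Cl)cccc2Cl)c1COc1ccc(-c2nc3ccc(C(=O)O)cc3n2CC(C)(C)C)cc1` gives 13 nM in an assay on Huh-7 cells for agonist activity at Bile acid receptor (Homo sapiens), read by a luciferase reporter; on this read-out higher numbers stand for an effect only at larger amounts of compound and lower numbers for an effect already at smaller amounts.
compound 2 `CC(C)c1onc(-c2c(Cl)cccc2Cl)c1COc1ccc(-c2nc3ccc(C(=O)O)cc3n2C(C)C)cc1` gives 3.39 nM in this assay.

Among the compounds with values here, the only step between measured compounds is a 3.8-fold lower number from compound 1 to compound 2 (0.58 log units; beyond the scatter). On the two numbers at hand, compound 2 stands at the lower one; the value of compound 1 lies beyond the scatter from it.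

Compound 3 `CC(=O)C1CCC(Cn2c(-c3ccc(OCc4c(-c5c(Cl)cccc5Cl)noc4C(C)C)cc3)nc3ccc(C(=O)O)cc32)CC1` has not yet been measured in this assay. It differs from compound 2 in one place: (4-acetylcyclohexyl)methyl in place of isopropyl on an aromatic nitrogen. Within the data shown here, the step from compound 1 to compound 2 is the one measured change at this nitrogen, and it shows the smaller of the two groups giving the lower number. Among the measured compounds shown here, the group entering in compound 3 is larger than either and brings an acceptor for which no measured step exists, so the expectation rests on a single comparison. The number is expected to move upward, by roughly a 4.4-fold higher number from compound 2 to compound 3 (0.65 log units; beyond the scatter), with wide uncertainty in either direction. Compound 3 is therefore estimated at about 15 nM in this assay, expected to fall between 3 nM and 60 nM.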

Compound 3, half-maximal effective concentration: 1170 nM
Estimate against measurement, compound 3: 78-fold (1.89 log units) below; the measured number lies above the stated range.
By their numbers in this assay, from the lowest: compound 2; then compound 1; then compound 3.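

In this assay the aromatic nitrogen proves far less forgiving than the earlier pair indicated: a 350-fold higher number from compound 2 to compound 3 (2.54 log units; beyond the scatter) is a large step, whereas a 3.8-fold lower number from compound 1 to compound 2 (0.58 log units; beyond the scatter) is only a modest one. The saturated chain carbon bound to the aromatic nitrogen is common to compound 1 and compound 3, yet a 90-fold higher number from compound 1 to compound 3 (1.95 log units; beyond the scatter) is also large, so the rise does not depend on the isopropyl branch being lost and appears with 4-acetylcyclohexyl in place of tert-butyl on that carbon. Across the three compounds the number rises from isopropyl through neopentyl to (4-acetylcyclohexyl)methyl, and none of them goes against this order, although three compounds make only a narrow basis for a trend.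

The compounds shown do not separate the contribution of the six-membered ring from that of the acetyl group, a question that a plain cyclohexylmethyl group, or a hydroxyl, an amine or a carboxylic acid in place of the acetyl, would address. No supporting data bear on why the number rises so steeply at this position.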